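The compounds below may be only part of what the source reports. "The series", "measured", "known", "first", "only" and "open" are said of these compounds alone.

Working notes on the series. Compound 1 `CC1CCC(=NNc2cc(Cl)cc(Cl)c2)c2ncc(C(=O)O)c(=O)n21` is the reference point for the step under review. In a functional assay on the whole organism with Rattus norvegicus as the target (a higher number here means that more compound is needed for the effect, a lower number that less compound is needed), compound 1 gives > 100 umol/kg, which is a limit of the assay and not a numbered result. Compound 1 thus sits at the limit of > 100 umol/kg in this assay, at which 1 of the 2 values shown sits. The other measured member, compound 2 `CC1CCC(=NNc2cccc3ccccc23)c2ncc(C(=O)O)c(=O)n21`, shares the core and differs only in the group on the hydrazone nitrogen. In this assay compound 2 gives > 320 umol/kg, again a limit of the assay rather than a number. That limit is the limit of > 320 umol/kg in this assay, at which 1 of the 2 values shown sits. Where compound 1 stands is therefore known only as a limit, and the one further value shown is also a limit; no numbered value exists in the set.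

The unmeasured compound 3 `CNN=C1CCC(C)n2c1ncc(C(=O)O)c2=O` differs from compound 1 in one place: methyl in place of 3,5-dichlorophenyl on an amine nitrogen. For the measured compounds named here, no step between measured compounds is available to scale this change, so the expectation rests on the two limits alone. The expected step from compound 1 to compound 3 in this assay is a step that the limit leaves unreadable from compound 1 to compound 3, with no direction beyond the scatter anticipated. Compound 3 is estimated at 150 umol/kg, within 30 umol/kg to 700 umol/kg, with a fair chance that only a limit is reported again.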

Compound 3, dose for 50% inhibition: > 100 umol/kg
Compound 3: only a limit was reported (the forecaster's own chance of this, stated with the estimate: 65%); the middle value lies beyond the limit too.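

Compound 1 and compound 3 are both known only as limits of the assay, so no step from one to the other can be read: the limit of > 100 umol/kg in this assay, at which 2 of the 3 values shown sit.

The compounds shown leave open whether methyl and 3,5-dichlorophenyl on the amine nitrogen differ at all in this assay; none of the compounds has a numbered value there.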